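The source may report more compounds than this note shows. Statements on the series, on what has been measured and on what is new or still open speak of the compounds shown alone.

Compound 1 `CCn1c(C(=O)NCCC(=O)OC)ccc1C(CC)(CC)c1ccc(OCS(=O)(=O)c2ccccc2)c(C)c1` — a limit in a functional assay on BXPC-3 cells (Homo sapiens) for antiproliferative activity, read by MTT assay, with a stated time of 24 h; a lower number here means a stronger inhibitor, a higher number a weaker inhibitor: compound 1 gives > 50000 nM.
Compound 2 `CCn1c(C(=O)N[C@H](CO)C(C)C)ccc1C(CC)(CC)c1ccc(OCS(=O)(=O)c2ccccc2)c(C)c1` — compound 2 gives 7720 nM.
Compound 3 `CCn1c(C(=O)NCCCO)ccc1C(CC)(CC)c1ccc(OCS(=O)(=O)c2ccccc2)c(C)c1` — compound 3 gives 26600 nM.

Among the numbers that are not limits, compound 3 stands highest, and its nearest neighbour is compound 2 a 3.4-fold higher number from compound 2 to compound 3 (0.54 log units; beyond the scatter). Compound 1 contributes only a limit (the limit of > 50000 nM in this assay, at which 1 of the 3 values shown sits). The step from compound 1 to compound 2 an at least 6.4-fold lower number from compound 1 to compound 2 (0.81 log units; beyond the scatter) and the step from compound 1 to compound 3 an at least 1.8-fold lower number from compound 1 to compound 3 (0.27 log units; that floor lies within the scatter) both start from that limit, so only their floors are known.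

Compound 4 `CCn1c(C(=O)N[C@H](C(=O)O)C(C)C)ccc1C(CC)(CC)c1ccc(OCS(=O)(=O)c2ccccc2)c(C)c1` differs from compound 3 in one place: 1-carboxy-2-methylpropyl in place of 3-hydroxypropyl on an amide-type nitrogen. Among the compounds with values here, the step that bears on this most directly is the one from compound 2 to compound 3 a 3.4-fold higher number from compound 2 to compound 3 (0.54 log units; beyond the scatter), which shows that the branched 1-(hydroxymethyl)-2-methylpropyl side chain gave a lower number than 3-hydroxypropyl. Within the data shown here, compound 4 carries the same branching, but with a carboxy group where compound 2 carried a hydroxymethyl, and no measured pair shows what that exchange does. A modest move downward from compound 3 is therefore expected, but with wide uncertainty: compound 4 is estimated at 12000 nM, between 4000 nM and 40000 nM, which would mean an expected step of a 2.2-fold lower number from compound 3 to compound 4 (0.35 log units; beyond the scatter).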

Compound 4, half-maximal inhibitory concentration: 16200 nM
Compound 4: the middle estimate sits 1.4-fold (0.13 log units) below what was measured, within the range that was stated.
By their numbers in this assay, from the lowest: compound 2; then compounds 4 and 3 (each within the scatter of the next). At a limit, above all of these: compound 1.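

In this assay, the exchange of hydroxymethyl for carboxy on the branched side chain can now be read directly, and it gives a 2.1-fold higher number from compound 2 to compound 4 (0.32 log units; beyond the scatter), so the lower number of compound 2 does not carry over to the carboxy analogue. Set against the 3-hydroxypropyl chain, the 1-carboxy-2-methylpropyl chain gives a 1.6-fold lower number from compound 3 to compound 4 (0.22 log units; within the scatter), so these two side chains on the amide-type nitrogen are not told apart in this assay, and the branching seen with compound 2 brings no readable gain once carboxy is present. The step of an at least 3.0-fold lower number from compound 1 to compound 4 (0.48 log units; beyond the scatter) starts from a limit and so gives only a floor, though that floor lies beyond the scatter: the limit of > 50000 nM in this assay, at which 1 of the 4 values shown sits.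

The compounds shown leave open how an amine or a primary carboxamide would behave in place of the hydroxymethyl or carboxy group on the same branched chain. They also leave open whether a longer chain carrying a hydroxyl would go lower than compound 2, and what the opposite configuration at the defined stereocentre would do.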